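This account rests on a few compounds, and the source may have more. Where it says the series, first, only, none or still open, it means among the compounds named here.

Measured so far:
Compound 1 `Cc1cc(NC(C)C)nc(SCc2nc3ccccc3[nH]2)n1`: > 100000 nM
Compound 2 `Cc1cc(Nc2ccc(Cl)cc2)nc(SCc2nc3ccccc3[nH]2)n1`: 36000 nM

In a functional assay on PC-3 cells (Homo sapiens) for cytotoxicity, read by MTT assay, with a stated time of 72 h (on this read-out lower numbers stand for stronger inhibition and higher numbers for weaker inhibition), compound 1 reaches only a limit, > 100000 nM. Compound 2 gives 36000 nM, the single number shown in this assay. Among the compounds with values here, the one measured step is an at least 2.7-fold lower number from compound 1 to compound 2 (0.44 log units; beyond the scatter). Compound 3 `Cc1cc(N2CCCCC2)nc(SCc2nc3ccccc3[nH]2)n1` differs from compound 2 by piperidin-1-yl in place of (4-chlorophenyl)amino on an aromatic carbon. That change removes the 4-chlorophenyl group whose arrival lowered the number in the step from compound 1 to compound 2, so the number for compound 3 is expected to rise again, a 2.2-fold higher number from compound 2 to compound 3 (0.35 log units; beyond the scatter). Compound 3 is therefore estimated at 80000 nM, with a likely range from 30000 nM to 200000 nM.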

Compound 3, half-maximal inhibitory concentration: > 100000 nM
Compound 3: a limit, no number (the forecaster's own chance of this, stated with the estimate: 40%); at least 1.2-fold (0.09 log units) between middle value and limit.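

In this assay, an at least 2.7-fold higher number from compound 2 to compound 3 (0.44 log units; beyond the scatter) comes with piperidin-1-yl in place of (4-chlorophenyl)amino, so a second group without the aromatic ring joins isopropylamino in giving no number. This change also removes the hydrogen-bond donor, which the step from isopropylamino kept. The step between compound 1 and compound 3 cannot be read, because both values are limits: the limit of > 100000 nM in this assay, at which 2 of the 3 values shown sit.

Going by these compounds, whether the chlorine, the aromatic ring or the amine hydrogen matters remains open. A plain phenylamino group or a cyclohexylamino group at this position would help separate them.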